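This account rests on a few compounds, and the source may have more. Where it says the series, first, only, none or still open, it means among the compounds named here.

Compound 1, `Cc1ccc(-c2cs/c(=N/NC(=O)CSc3nnnn3C)n2-c2ccccc2)cc1`, gives 243 ug/mL in an ADME assay on NIH3T3 cells (Mus musculus) for cytotoxicity, read by MTT assay, with a stated time of 24 h; on this read-out higher numbers stand for weaker inhibition and lower numbers for stronger inhibition. Compound 2, `Cn1nnnc1SCC(=O)N/N=c1/scc(-c2ccc([N+](=O)[O-])cc2)n1-c1ccccc1`, gives 167 ug/mL in this assay.

These are the only two numbers so far, and they sit close together: the step of a 1.5-fold lower number from compound 1 to compound 2 (0.16 log units; within the scatter) does not separate the two compounds, so on the numbers shown compound 2 stands alongside compound 1 rather than apart from it.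

Compound 3, `Cn1nnnc1SCC(=O)N/N=c1/scc(-c2ccc(Cl)cc2)n1-c1ccccc1`, has not yet been measured. It differs from compound 2 in one place: chloro in place of nitro on an aromatic carbon. For the measured compounds named here, the one measured step that bears on this position is the exchange of groups on the same aromatic carbon, a 1.5-fold lower number from compound 1 to compound 2 (0.16 log units; within the scatter), which lay within the scatter. Going by the values given here, with only that comparison to go on, a second exchange at the same carbon is expected to give no step beyond the scatter in this assay, in either direction; the expected step is a 1.2-fold higher number from compound 2 to compound 3 (0.08 log units; within the scatter). Compound 3 is therefore estimated at 200 ug/mL in this assay, with a range from 100 ug/mL to 400 ug/mL.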

Compound 3, half-maximal inhibitory concentration: 40 ug/mL
The estimate for compound 3 lay 5.0-fold (0.70 log units) above the measured number; the measured number lies below the stated range.
By their numbers in this assay, from the lowest: compound 3; then compounds 2 and 1 (each within the scatter of the next).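

The aromatic carbon para to a large group turns out not to be indifferent in this assay: the earlier exchange there, a 1.5-fold lower number from compound 1 to compound 2 (0.16 log units; within the scatter), stayed within the scatter, but chloro opens real gaps, with a 4.2-fold lower number from compound 2 to compound 3 (0.62 log units; beyond the scatter) and a 6.1-fold lower number from compound 1 to compound 3 (0.78 log units; beyond the scatter), both modest yet beyond the scatter. Nitro and methyl cannot be told apart at this carbon, while chloro stands apart from both, so compound 3 gives the strongest inhibition of the three and the similar numbers of the first pair did not hold for every exchange at this position. No measurement at hand accounts for this shift, so the data record the size of the change and not its origin.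

The compounds shown leave open whether the lower number belongs to chloro alone or would also appear with fluoro, bromo, methoxy or an amine on the same carbon. They also leave open whether the 4-nitrophenyl to 4-chlorophenyl change would give a step of similar size with a different group in place of the unsubstituted phenyl that all three compounds share.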